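Thiophene-amine series: removing the 1-methylethenyl group

The compounds below may be only part of what the source reports. "The series", "measured", "known", "first", "only" and "open" are said of these compounds alone.

Three compounds on the shared core of compound 1 `Cc1ccsc1CN[C@@H]1C[C@H]2C[C@@H]([C@H]1C)C2(C)C` carry a different group on the thiophene ring. In an ADME assay on MDCK cells (Canis lupus familiaris) for cytotoxicity, read by microscopy, with a stated time of 48 h (a lower number here means that less compound is tolerated, a higher number that more compound is tolerated), compound 1 gives 10000 nM. Compound 2 `C[C@H]1[C@H](NCc2ccc(C(C)(C)C)s2)C[C@H]2C[C@@H]1C2(C)C` gives 780 nM. Compound 3 `C=C(C)c1csc(CN[C@@H]2C[C@H]3C[C@@H]([C@H]2C)C3(C)C)c1` gives 25000 nM, the highest number of the three; compound 1 stands nearest below it, beyond the scatter, and compound 2 furthest below it, also beyond the scatter. Across these three, the smaller groups on the thiophene go with higher numbers, compound 2 being the only compound with a large group and the lowest number.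

Compound 4 `C[C@H]1[C@H](NCc2cccs2)C[C@H]2C[C@@H]1C2(C)C` has not been measured. It differs from compound 3 as follows: hydrogen in place of 1-methylethenyl on an aromatic carbon

Among the measured compounds shown here, no step between measured compounds isolates this change, so its size is not known from the data. Given that compound 1 with its small methyl group gives 10000 nM and compound 3 gives 25000 nM, the step from compound 3 to compound 4 is expected to be small, towards a somewhat lower number, and may fall within the scatter: a 1.7-fold lower number from compound 3 to compound 4 (0.22 log units; within the scatter). For compound 4 the expected value in this assay is 15000 nM, with a range from 5000 nM to 45000 nM.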

Compound 4, minimum cytotoxic concentration: 25000 nM
Estimate against measurement, compound 4: 1.7-fold (0.22 log units) below, within the range that was stated.
By their numbers in this assay, from the lowest: compound 2; then compound 1; then compounds 3 and 4 (each within the scatter of the next).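

Removing the 1-methylethenyl group leaves this assay unmoved, with no change at the digits printed from compound 3 to compound 4 (within the scatter), so on this aromatic carbon, two ring bonds from the ring sulfur, the group can be lost with no readable gain or cost. Other replacements by hydrogen do move the number: hydrogen in place of tert-butyl gives a 32-fold higher number from compound 2 to compound 4 (1.51 log units; beyond the scatter), and hydrogen in place of methyl gives a 2.5-fold higher number from compound 1 to compound 4 (0.40 log units; beyond the scatter). Compound 4 therefore gives the series a reference without a group on the thiophene, and the earlier link between smaller groups and higher numbers does not hold as a simple rule: compound 3 goes against it, since losing 1-methylethenyl brings no change while losing the smaller methyl of compound 1 does.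

Nothing in the data gives a measured reason for these differing steps.

As far as these compounds go, whether an amine, a carboxylic acid or a longer chain on this same aromatic carbon would keep the number stays open, as does whether any group other than tert-butyl would bring a step of that size.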